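From Furyl Ketone to Ethyl Ester on the Exocyclic Alkene

The source may hold more compounds than are shown below. What is called first, only, known or untested is meant among the compounds shown, and "the series" means these compounds.

In a functional assay on A-375 cells (Homo sapiens) for cytotoxicity, read by MTT assay, with a stated time of 48 h (a higher number here means a weaker inhibitor, a lower number a stronger inhibitor), compound 2 `CC1(C)S[C@@H]2/C(=C\C(=O)c3ccco3)C(=O)N2[C@H]1C(=O)OC(c1ccccc1)c1ccccc1` gives 26000 nM, the second highest of the three numbers measured. Compound 1 `CC1(C)S[C@@H]2/C(=C\C(=O)c3ccc4ccccc4c3)C(=O)N2[C@H]1C(=O)OC(c1ccccc1)c1ccccc1` gives 36500 nM and compound 3 `CC1(C)[C@H](C(=O)OC(c2ccccc2)c2ccccc2)N2C(=O)/C(=C/C(=O)c3ccccc3)[C@H]2S1(=O)=O` gives 17500 nM, both within the scatter of compound 2. Within the data shown here, the only single-point step recorded, a 1.4-fold lower number from compound 1 to compound 2 (0.15 log units; within the scatter), swaps one aromatic group for another on the carbonyl carbon. Compound 4 `CCOC(=O)/C=C1/C(=O)N2[C@@H]1SC(C)(C)[C@@H]2C(=O)OC(c1ccccc1)c1ccccc1` differs from compound 2 by ethoxy in place of furan-2-yl on a carbonyl carbon. Among the measured compounds shown here, no measured step replaces the ketone by an ester, so the data give no direct guide; the nearest step stayed within the scatter. Compound 4 is therefore expected to give 30000 nM, ranging from 12000 nM to 75000 nM. That expectation amounts to a 1.2-fold higher number from compound 2 to compound 4 (0.06 log units; within the scatter), within the scatter.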

Compound 4, half-maximal inhibitory concentration: 7000 nM
Compound 4: the middle estimate sits 4.3-fold (0.63 log units) above what was measured, outside the stated range (below it).
By their numbers in this assay, from the lowest: compound 4; then compounds 3, 2 and 1 (each within the scatter of the next, the first and the last beyond it).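

In this assay, the place on a carbonyl carbon whose other neighbour is the double-bonded chain carbon now shows steps beyond the scatter: ethoxy in place of furan-2-yl (a 3.7-fold lower number from compound 2 to compound 4 (0.57 log units; beyond the scatter)) and ethoxy in place of naphthalen-2-yl (a 5.2-fold lower number from compound 1 to compound 4 (0.72 log units; beyond the scatter)). The earlier exchange of one aromatic group for the other (a 1.4-fold lower number from compound 1 to compound 2 (0.15 log units; within the scatter)) had stayed within the scatter. Nothing here accounts for the shift.

As far as these compounds go, whether the ester link or the loss of the ring matters remains open. A propyl ketone, an amine or a carboxylic acid at this place could help separate the two.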